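Cytotoxicity at the Limit: From Compound 3 to Compound 4

The compounds below may be only part of what the source reports. "The series", "measured", "known", "first", "only" and "open" are said of these compounds alone.

Compound 3 `O=[N+]([O-])c1cn2c(n1)OC(COc1ccc(-c3ccc(F)nc3F)cn1)CC2` was tested in an ADME assay on MRC5 cells (Homo sapiens) for cytotoxicity, read by resazurin assay, with a stated time of 72 h; on this read-out higher numbers stand for weaker inhibition and lower numbers for stronger inhibition. In this assay compound 3 gives > 64000 nM, which is a limit of the assay and not a number. Its methyl-bearing relative, compound 1 `CC1(COc2ccc(-c3ccc(F)nc3F)cn2)CCn2cc([N+](=O)[O-])nc2O1`, stands the same way. In this assay compound 1 gives > 64000 nM, again a limit. Compound 2 `CC1(COc2ccc(-c3ccc(F)cc3)cc2)CCn2cc([N+](=O)[O-])nc2O1` is the third measured member of the set. In this assay compound 2 gives > 64000 nM, also a limit. The step that the two limits leave unreadable from compound 1 to compound 3 therefore cannot be read, since both of its ends sit at the limit, and the limit of > 64000 nM in this assay, at which 3 of the 3 values shown sit, marks the place where all three values stand. Among the compounds with values here, compound 3 thus stands level with the others, at the limit, and no measured step in the set has a readable size.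

Compound 4 `O=[N+]([O-])c1cn2c(n1)OC(COc1ccc(-c3ccc(F)cn3)cn1)CC2` differs from compound 3 in a single place: 5-fluoropyridin-2-yl in place of 2,6-difluoropyridin-3-yl on an aromatic carbon. Within the data shown here, no measured step bears on this change in a readable way, because a step that the two limits leave unreadable from compound 1 to compound 3 is itself unreadable. Given that every measured value sits at the limit, compound 4 is expected to sit there as well, with no step beyond the scatter. The step of a number no higher from compound 3 to compound 4 (the limit leaves the size open) is the one this estimate means. The estimate for compound 4 is 64000 nM, with a range from 30000 nM to 130000 nM.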

Compound 4, half-maximal inhibitory concentration: > 64000 nM
Compound 4: no number, only a limit; the forecaster's own chance of this, stated with the estimate: 85%; the middle value lies on the limit itself.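

No step can be read from compound 3 to compound 4, and in this assay both compounds remain at a limit of the assay rather than at a number: the limit of > 64000 nM in this assay, at which 4 of the 4 values shown sit.

The compounds shown leave open how far each one's true value lies past that limit, and whether any of these changes of group alters the read-out at all.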